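Trimming One Carbon from the Side Chain of Compound 2

The compounds below may be only part of what the source reports. "The series", "measured", "known", "first", "only" and "open" are said of these compounds alone.

Of the compounds shown here, three have so far been measured in a functional assay on MDA-MB-231 cells (Homo sapiens) for cytotoxicity, read by MTT assay, with a stated time of 72 h, tested at 1 uM, in the absence of a further agent; on this read-out higher numbers stand for a weaker effect at the one concentration tested and lower numbers for a stronger effect. Compound 1 `CC1(C)CC(=S)Nc2ccc(Cl)cc21` gives 85.7%. Compound 2 `CC1(C)CC(NCCCCO)=Nc2ccc(Cl)cc21` gives 87.6%, the highest of the three numbers; compound 1 lies within the scatter of it, whereas compound 3 `CN(C)CCCNC1=Nc2cc(Cl)ccc2C(C)(C)C1` gives 68.4%, beyond the scatter and the furthest away. Compound 4 `CC1(C)CC(NCCCO)=Nc2ccc(Cl)cc21` has not been measured. It differs from compound 2 in one place: hydroxy in place of hydroxymethyl on a saturated chain carbon, three bonds along the chain from an amine nitrogen. Among the compounds with values here, no measured pair shows this kind of change, so there is no precedent to lean on. Because compound 2 gives 87.6% and the change is small, the step of a number 2.6 percentage points lower from compound 2 to compound 4 (within the scatter) is expected to stay within the scatter. Compound 4 is estimated at 85%, with a range from 72% to 96%.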

Compound 4, a percentage reported as activity, at one concentration (the size of the read-out at that concentration, not a potency): 84.5%
The estimate for compound 4 lay 0.5 percentage points above the measured number, within the range that was stated.
By their numbers in this assay, from the lowest: compound 3; then compounds 4, 1 and 2 (each within the scatter of the next).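

In this assay, this first measured pair at this position gives a number 3.1 percentage points lower from compound 2 to compound 4 (within the scatter), so the 4-hydroxybutyl and 3-hydroxypropyl chains cannot be told apart on this read-out. The hydroxy-bearing chain therefore tolerates the loss of one carbon here, at least at the one concentration tested. Nothing at hand explains this result.

As far as these compounds go, what an amine or a carboxylic acid in place of the hydroxy would give on this chain remains open. So does the 2-hydroxyethyl chain, which would show whether further trimming stays equally silent.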